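Solubility notes on the pyridin-2-yl ether side chain

The source may report more compounds than this note shows. Statements on the series, on what has been measured and on what is new or still open speak of the compounds shown alone.

Compound 1 `Cn1c(C(F)(F)F)ccc(NCc2cc3cc(Cl)ccc3[nH]c2=O)c1=O` gives only a limit in a physicochemical assay for solubility (on this read-out lower numbers stand for lower solubility and higher numbers for higher solubility), namely < 100 nM (the limit of < 100 nM in this assay, at which 1 of the 3 values shown sits). Compound 2 `COc1cccc(NCc2cc3cc(Cl)ccc3[nH]c2=O)c1` gives 280 nM in this assay. Compound 3 `C[C@H](Nc1ccc(C#N)n(C)c1=O)c1cc2cc(Cl)c(O[C@H](C)c3ccccn3)cc2[nH]c1=O` gives 1600 nM in this assay, the highest of the two numbers shown; its nearest neighbour is compound 2, and that gap lies beyond the scatter. Compound 4 `C[C@H](Nc1ccc(C#N)n(C)c1=O)c1cc2cc(Cl)c(OCc3ccccn3)cc2[nH]c1=O` differs from compound 3 by hydrogen in place of methyl on a saturated chain carbon bound to an aromatic carbon and an oxygen on an aromatic ring. Going by the values given here, no pair of the three measured compounds shows this change, so no measured step guides it. The step is expected to be small, a 1.1-fold higher number from compound 3 to compound 4 (0.05 log units; within the scatter), and not beyond the scatter in either direction. Compound 4 is therefore estimated at 1800 nM in this assay, with a range from 700 nM to 4500 nM.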

Compound 4, solubility: 2500 nM
Compound 4: the middle estimate sits 1.4-fold (0.14 log units) below what was measured, within the range that was stated.
By their numbers in this assay, from the lowest: compound 2; then compounds 3 and 4 (each within the scatter of the next). At a limit, below all of these: compound 1.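

In this assay, going by these compounds alone, the change from 1-(pyridin-2-yl)ethoxy to (pyridin-2-yl)methoxy gives a 1.6-fold higher number from compound 3 to compound 4 (0.19 log units; within the scatter) and is the first step read at this position. The methyl on this saturated chain carbon can therefore give way to hydrogen with no difference beyond the scatter. Nothing at hand gives a cause for this step.

On these data alone, whether a larger group on the same carbon, such as an ethyl or a hydroxymethyl, would move the number beyond the scatter stays open. So does the effect of an amine on the pyridin-2-yl ring.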